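A few compounds are considered here, and "the series" means these few. Any claim that something is new, unique, unknown or untested is made for them only; others in the source may bear on it.

Among the measured compounds shown here, the three compounds measured so far share one core and differ only in the group that sits on a saturated ring carbon. Compound 1 `Cc1cc(O)c(C2=NN(c3ccc(S(N)(=O)=O)cc3)C(c3ccccc3Cl)C2)cc1Cl` carries a 2-chlorophenyl there, and in a functional assay on OVCAR-5 cells (Homo sapiens) for antiproliferative activity, with a stated time of 48 h (a higher number here means a weaker inhibitor of growth, a lower number a stronger inhibitor of growth), compound 1 gives 1740 nM. Compound 2 `Cc1cc(O)c(C2=NN(c3ccc(S(N)(=O)=O)cc3)C(/C=C/c3ccccc3)C2)cc1Cl` carries a 2-phenylethenyl, and in this assay compound 2 gives 3180 nM. Compound 3 `COc1ccc(C2CC(c3cc(Cl)c(C)cc3O)=NN2c2ccc(S(N)(=O)=O)cc2)cc1OC` carries a 3,4-dimethoxyphenyl, and in this assay compound 3 gives 2250 nM, the second highest of the three numbers; compound 1 is its nearest neighbour and compound 2 its furthest, and both gaps lie within the scatter. The steps of a 1.8-fold higher number from compound 1 to compound 2 (0.26 log units; within the scatter), a 1.3-fold higher number from compound 1 to compound 3 (0.11 log units; within the scatter) and a 1.4-fold lower number from compound 2 to compound 3 (0.15 log units; within the scatter) are all within the scatter, so the group on the saturated ring carbon has so far made no difference that this assay can resolve.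

Compound 4 `COc1ccc(C2CC(c3cc(Cl)c(C)cc3O)=NN2c2ccc(S(N)(=O)=O)cc2)c(OC)c1OC` differs from compound 3 by methoxy in place of hydrogen on an aromatic carbon, so that a 3,4-dimethoxyphenyl becomes a 2,3,4-trimethoxyphenyl. For the measured compounds named here, no measured step alters this ring itself; the three steps that bear on it are the swaps of the whole group, and none of them reached beyond the scatter. Compound 4 is therefore expected to show no step beyond the scatter, that is a 1.0-fold higher number from compound 3 to compound 4 (0.01 log units; within the scatter). The estimated value of compound 4 in this assay is 2300 nM, with a range from 1000 nM to 5500 nM.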

Compound 4, concentration for 50% growth inhibition: 1870 nM
Estimate against measurement, compound 4: 1.2-fold (0.09 log units) above; the measured number falls inside the stated range.
By their numbers in this assay, from the lowest: compounds 1, 4, 3 and 2 (each within the scatter of the next).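

Methoxy in place of hydrogen is the only step shown that alters the aromatic ring itself rather than swapping the whole group on the saturated ring carbon, and in this assay it gives a 1.2-fold lower number from compound 3 to compound 4 (0.08 log units; within the scatter). A methoxy on this aromatic carbon, ortho to a large group, ortho to one methoxy group and meta to another, therefore makes no difference that this assay can resolve, and the 2,3,4-trimethoxyphenyl group also stays within the scatter of the other two groups, with a 1.7-fold lower number from compound 2 to compound 4 (0.23 log units; within the scatter) and a 1.1-fold higher number from compound 1 to compound 4 (0.03 log units; within the scatter). No measurement of any property of these groups bears on this result.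

The compounds shown leave open whether a group of another kind on the saturated ring carbon, such as an amine, a carboxylic acid or a longer chain, would move the number beyond the scatter. From the compounds shown here alone, the rest of the shared core is the same in all four compounds, so the effect of a change there also remains open.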